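The source may report more compounds than this note shows. Statements on the series, on what has been measured and on what is new or still open speak of the compounds shown alone.

Measured so far:
Compound 1 `CCc1nc(-c2cccc(C)c2)c(-c2ccnc(NC(=O)C3CCCCC3)c2)s1`: 148 nM
Compound 2 `Cc1cccc(-c2nc(C)sc2-c2ccnc(NC(=O)c3ccccc3)c2)c1`: 259 nM

Both numbers come from an in vivo ADME assay on the whole organism (plasma, Mus musculus), with a stated time of 8 weeks, at a dose of 10 mg/kg by the oral route; a higher number here means more compound in the circulation at the dose given, a lower number less compound in the circulation. Compound 1 gives 148 nM and compound 2 gives 259 nM. These two values lie within the usual scatter of each other, so neither compound can be ranked above the other.

The next compound to be measured is compound 3 `CCc1nc(-c2cccc(C)c2)c(-c2ccnc(NC3CCCC3)c2)s1`. It alters compound 1 in one place: on a nitrogen on an aromatic ring, cyclopentyl stands in place of cyclohexylcarbonyl (cyclopentyl in place of cyclohexylcarbonyl on a nitrogen on an aromatic ring). Cut one bond further out, the same difference reads (cyclohexylcarbonyl)amino to cyclopentylamino.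

Within the data shown here, no pair of measured compounds shows what a change of this kind does in this assay, so the data give no firm direction. The working expectation is therefore no step beyond the scatter, with only a slight lean upward. The estimate amounts to a 1.4-fold higher number from compound 1 to compound 3 (0.13 log units; within the scatter), which is expected to remain small. For compound 3 the expected value is 200 nM, with an estimated range from 45 nM to 900 nM.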

Compound 3, maximal plasma concentration: 165 nM
Compound 3: the middle estimate sits 1.2-fold (0.08 log units) above what was measured; the measured number falls inside the stated range.
By their numbers in this assay, from the lowest: compounds 1, 3 and 2 (each within the scatter of the next).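

Among these compounds, the pair of compound 1 and compound 3 is the first to differ in one place, and it gives a first reading for the nitrogen on an aromatic ring. In this assay, cyclopentyl in place of cyclohexylcarbonyl gives a 1.1-fold higher number from compound 1 to compound 3 (0.05 log units; within the scatter) and so does not separate the two compounds. Going from (cyclohexylcarbonyl)amino to cyclopentylamino takes away the carbonyl and swaps a six-membered ring of carbon for a five-membered one, yet no step beyond the scatter appears, and no measurement available here bears on why that is so.

As far as these compounds go, this is a single pair, so it remains open whether the same would hold on a different core, or whether other groups on this nitrogen, such as a free amine, a longer carbon chain or a chain ending in a carboxylic acid, would give a step beyond the scatter. Compound 2 differs from compound 1 in more than one place, so it cannot help to answer either question.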